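Adding Chlorine to the Carboxyphenyl End of Compound 1

This account rests on a few compounds, and the source may have more. Where it says the series, first, only, none or still open, it means among the compounds named here.

Compound 1 `Cc1c(OCCCCOc2ccc(C(=O)O)cc2)ccc(C(=O)CC2CCCC2)c1O` is the starting point. For the measured compounds named here, in an assay on HEK293 cells for positive allosteric modulation of metabotropic glutamate receptor 3 (Rattus norvegicus), read by thallium flux, with a stated time of 2.5 min (a lower number here means a smaller maximal response, a higher number a larger maximal response), compound 1 gives 26.7%, which stands second highest of the three numbers measured so far. Compound 2 `Cc1c(OCCCCOc2ccc(C(=O)O)cc2)ccc(C(=O)CC2CCCC2)c1C` gives 12.2%, and the step of a number 14.5 percentage points lower from compound 1 to compound 2 (beyond the scatter) arises from a methyl in place of hydroxy on an aromatic carbon. Compound 3 `Cc1c(OCCCCOc2ccc(C(=O)CC(C)(C)C)c(O)c2C)cccc1C(=O)O` gives 109%, far above compound 1.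

Compound 4 `Cc1c(OCCCCOc2ccc(C(=O)O)c(Cl)c2)ccc(C(=O)CC2CCCC2)c1O` has not yet been measured. It differs from compound 1 by chloro in place of hydrogen on an aromatic carbon. Going by the values given here, none of the measured steps touches the 4-carboxyphenyl part of the molecule: the only single change measured, from compound 1 to compound 2, alters a different part and cannot show how a chloro entering here would act. Compound 3 differs from compound 1 in several places at once, so its value gives no guide for this one change either. With nothing to support a shift, the expectation for compound 4 is a step of about a number 3.3 percentage points higher from compound 1 to compound 4 (within the scatter), not beyond the scatter. Compound 4 is therefore estimated at 30%, in a range from 10% to 60%.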

Compound 4, largest response reached (reported as percent of maximum), in percent of the reference or control that the assay uses: 40%
Compound 4: the middle estimate sits 10 percentage points below what was measured, within the range that was stated.
By their numbers in this assay, from the lowest: compound 2; then compound 1; then compound 4; then compound 3.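

This is the first change shown at the 4-carboxyphenyl end of the molecule, and in this assay the move to 4-carboxy-3-chlorophenyl gives a number 13.3 percentage points higher from compound 1 to compound 4 (beyond the scatter). The end that carries the carboxy group can therefore influence the maximal response, and a single chloro, ortho to a carboxy group, is enough to move it beyond the usual scatter. Nothing available explains why the response rises with this change.

From the compounds shown here alone, it remains open whether a fluoro, a bromo or a methoxy group on the same aromatic carbon would raise the response as well, or whether a chloro would do so on another carbon of this ring. Going by these compounds, it is also open whether the chloro would bring a similar gain in the shared core of compound 2, which carries a methyl in place of the hydroxy.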